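Replacing 2-hydroxyethyl with 4-hydroxypiperidin-1-yl on a sulfonyl sulfur

A few compounds are considered here, and "the series" means these few. Any claim that something is new, unique, unknown or untested is made for them only; others in the source may bear on it.

Compound 1 (`O=S(=O)(NCC1COC1)c1cccc(-c2ccc3nccc(-c4ccncc4)c3n2)c1`): 19%
Compound 2 (`O=S(=O)(CCO)c1cccc(-c2ccc3nccc(-c4ccncc4)c3n2)c1`): 52%

In an ADME assay on microsomes from liver (Mus musculus) for metabolic stability, read by LC-MS, using NADPH, with a stated time of 30 min, tested at 0.1 uM (a lower number here means that less of the compound is left, a higher number that more of the compound is left), compound 2 stands highest of the two measured compounds at 52%. Compound 3 (`O=S(=O)(c1cccc(-c2ccc3nccc(-c4ccncc4)c3n2)c1)N1CCC(O)CC1`) has not yet been measured, and it differs from compound 2 by 4-hydroxypiperidin-1-yl in place of 2-hydroxyethyl on a sulfonyl sulfur. Among the measured compounds shown here, one measured step bears on this change, though only indirectly. It is a number 33 percentage points higher from compound 1 to compound 2 (beyond the scatter), a large step in which 2-hydroxyethyl took the place of ((oxetan-3-yl)methyl)amino on the sulfonyl sulfur. For the measured compounds named here, compound 3 again carries a nitrogen-containing group there, as compound 1 does, but no measured step tests 4-hydroxypiperidin-1-yl itself. Part of the gain seen in a number 33 percentage points higher from compound 1 to compound 2 (beyond the scatter) is therefore expected to be lost, giving a moderate fall. The expected step is a number 17 percentage points lower from compound 2 to compound 3 (beyond the scatter). For compound 3 the estimate is 35%, with the result expected between 16% and 56%.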

Compound 3, percent of the compound remaining: 7%
Estimate against measurement, compound 3: 28 percentage points above; the whole stated range lies above it.
By their numbers in this assay, from the lowest: compound 3; then compound 1; then compound 2.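

In this assay the group on the sulfonyl sulfur has a large say in the result: 4-hydroxypiperidin-1-yl in place of 2-hydroxyethyl gives a number 45 percentage points lower from compound 2 to compound 3 (beyond the scatter) and does not even match the ((oxetan-3-yl)methyl)amino group, as a number 12 percentage points lower from compound 1 to compound 3 (beyond the scatter) shows. Both groups that bond through nitrogen to the sulfonyl sulfur thus stand below 2-hydroxyethyl, and the hydroxy group shared by compound 2 and compound 3 did not by itself keep the higher number. No measurement at hand gives a reason for these differences.

The compounds shown leave open whether the loss goes with the nitrogen on the sulfur or with the ring, which an open-chain (2-hydroxyethyl)amino group would help to separate. A longer chain such as 3-hydroxypropyl on the sulfonyl sulfur also remains an open case.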